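Ring substitution on the amide-type nitrogen of compound 1

A few compounds are considered here, and "the series" means these few. Any claim that something is new, unique, unknown or untested is made for them only; others in the source may bear on it.

Compound 1 `O=C(NCCCCc1ccccc1)c1cccc(C2SCC(=O)N2c2ccccc2)c1` gives 68% in a functional assay on U2OS cells (Homo sapiens) for inhibition, read by CCK-8 assay, with a stated time of 72 h, tested at 1 uM; a lower number here means less inhibition, a higher number more inhibition at the concentration tested (going by the name of the read-out).
Compound 2 `COc1cccc(OC)c1N1C(=O)CSC1c1cccc(C(=O)NCCCCc2ccccc2)c1` gives 41% in this assay.
Compound 3 `O=C(NCCCCc1ccccc1)c1cccc(C2SCC(=O)N2c2ccccc2F)c1` gives 38% in this assay.

Compound 1 stands highest of the three; the step of a number 27 percentage points lower from compound 1 to compound 2 (beyond the scatter) and the step of a number 30 percentage points lower from compound 1 to compound 3 (beyond the scatter) are both beyond the scatter. Compound 4 `CC(F)(F)c1cccc(N2C(=O)CSC2c2cccc(C(=O)NCCCCc3ccccc3)c2)c1` differs from compound 1 by 1,1-difluoroethyl in place of hydrogen on an aromatic carbon, on the same ring that the two measured steps altered. Among the measured compounds shown here, both of those steps were modest falls in this assay, and no measured step on this ring raised the inhibition. A fall of similar size is therefore expected for compound 4, a step of a number 26 percentage points lower from compound 1 to compound 4 (beyond the scatter). Compound 4 is estimated at 42%, with a range from 25% to 62%.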

Compound 4, a percentage reported as inhibition, at one concentration (the size of the read-out at that concentration, not a potency): 24%
Estimate against measurement, compound 4: 18 percentage points above; the whole stated range lies above it.
By their numbers in this assay, from the lowest: compound 4; then compounds 3 and 2 (each within the scatter of the next); then compound 1.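

On this aromatic carbon, meta to a large group, 1,1-difluoroethyl in this assay brings a step of a number 44 percentage points lower from compound 1 to compound 4 (beyond the scatter) and so the largest fall seen on this ring. Compound 4 also stands apart from the two earlier substituted rings, with a number 14 percentage points lower from compound 3 to compound 4 (beyond the scatter) and a number 17 percentage points lower from compound 2 to compound 4 (beyond the scatter) as the steps. No measurement shown explains this fall.

The compounds shown leave open whether the fall follows from the group itself or from its place on the ring. A methyl, a chlorine, an amine or a carboxylic acid on this same carbon could show whether any group here keeps the inhibition of compound 1.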